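Aryl selenocyanate carbamates: varying the ester group

A few compounds are considered here, and "the series" means these few. Any claim that something is new, unique, unknown or untested is made for them only; others in the source may bear on it.

In a functional assay on PC-3 cells (Homo sapiens) for cytotoxicity, read by MTT assay, with a stated time of 72 h (a higher number here means a weaker inhibitor of growth, a lower number a stronger inhibitor of growth), compound 2 `N#C[Se]c1ccc(NC(=O)Oc2ccccc2)cc1` gives 37500 nM and stands within the scatter of compound 1 `C=CCOC(=O)Nc1ccc([Se]C#N)cc1`, which gives 44700 nM. Among the compounds with values here, the only measured step at this oxygen, a 1.2-fold lower number from compound 1 to compound 2 (0.08 log units; within the scatter), stayed within the scatter. Compound 3 `CCCCOC(=O)Nc1ccc([Se]C#N)cc1` differs from compound 2 by butyl in place of phenyl on an oxygen next to a carbonyl group. This change sits at the same oxygen as the measured step, and since a 1.2-fold lower number from compound 1 to compound 2 (0.08 log units; within the scatter) lies within the scatter, no step beyond the scatter is expected in this assay. Compound 3 is therefore estimated at 40000 nM (range 18000 nM to 90000 nM), an expected step of a 1.1-fold higher number from compound 2 to compound 3 (0.03 log units; within the scatter).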

Compound 3, concentration for total growth inhibition: 40800 nM
Compound 3: the middle estimate sits 1.0-fold (0.01 log units) below what was measured, within the range that was stated.
By their numbers in this assay, from the lowest: compounds 2, 3 and 1 (each within the scatter of the next).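

In this assay the six-membered aromatic ring can leave this oxygen in favour of butyl, which has no ring, with no step beyond the scatter (a 1.1-fold higher number from compound 2 to compound 3 (0.04 log units; within the scatter)). The saturated chain also stands within the scatter of the allyl group, with a 1.1-fold lower number from compound 1 to compound 3 (0.04 log units; within the scatter), so compounds 1, 2 and 3 show no separation at this oxygen. No evidence is available that bears on this flat result.

Still open, from the compounds shown here alone, is whether a longer chain, or a chain carrying an amine or a carboxylic acid, would give a step beyond the scatter at this oxygen.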